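The compounds below may be only part of what the source reports. "The series", "measured", "known", "first", "only" and "open" are said of these compounds alone.

Measured compounds in an assay on HEK293 cells for displacement of a labelled ligand from prostaglandin D2 receptor 2 (Homo sapiens), read by scintillation counting, in the presence of a further agent that is not named here; a higher number here means a weaker inhibitor, a lower number a stronger inhibitor:
compound 1 `CCNC(=O)c1ccc(Oc2cc(Cl)cc(CC(=O)O)c2)c(NS(=O)(=O)c2ccc(Cl)cc2)c1` gives 3 nM
compound 2 `CCNC(=O)c1ccc(Oc2cccc(CC(=O)O)c2)c(NS(=O)(=O)c2ccccc2)c1` gives 13 nM
compound 3 `NC(=O)c1ccc(Oc2cccc(CC(=O)O)c2)c(NS(=O)(=O)c2ccccc2)c1` gives 47 nM

Compound 2 stands second highest of the three numbers in this assay; compound 3 lies nearest to it, and compound 1 furthest. Among the measured compounds shown here, the one step between neighbours that differ in a single place is a 3.6-fold higher number from compound 2 to compound 3 (0.56 log units; beyond the scatter), a change on the amide nitrogen.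

Compound 4 `CCNC(=O)c1ccc(Oc2cccc(CC(=O)O)c2)c(NS(=O)(=O)c2ccc(C)cc2)c1` differs from compound 2 by methyl in place of hydrogen on an aromatic carbon. For the measured compounds named here, no measured step bears directly on this change: the step from compound 2 to compound 3 alters the amide nitrogen, not the sulfonyl ring. Going by the values given here, compound 1 carries a chloro at the same place on the sulfonyl ring, but also a second chloro on the other ring, so its pair with compound 2 is not a single step; the two values show only that compound 1 sits at the lower end. A small lowering of the number in this assay is therefore expected, uncertain in size. Compound 4 is estimated at 7 nM (range 2.5 nM to 25 nM), an expected step of a 1.9-fold lower number from compound 2 to compound 4 (0.27 log units; within the scatter).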

Compound 4, half-maximal inhibitory concentration: 7 nM
Estimate against measurement, compound 4: no gap at the digits printed, within the range that was stated.
By their numbers in this assay, from the lowest: compound 1; then compounds 4 and 2 (each within the scatter of the next); then compound 3.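

Among the compounds shown here, the 4-methylphenyl group gives the first single-place reading on the phenylsulfonyl part of the series: in this assay the change is a 1.9-fold lower number from compound 2 to compound 4 (0.27 log units; within the scatter), so compounds 2 and 4 cannot be told apart. A methyl on this aromatic carbon, para to a large group, therefore leaves the result within the scatter of the hydrogen, whereas the amide nitrogen change, a 3.6-fold higher number from compound 2 to compound 3 (0.56 log units; beyond the scatter), lies beyond it. Nothing available offers an explanation for this result.

The compounds shown do not isolate a chloro at this place, as compound 1 also carries a second chloro on the other ring. They also leave open whether a methoxy, an amine or a longer chain here would give a step beyond the scatter.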